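Bromo in Place of Trifluoromethyl on the Anilino Ring

A few compounds are considered here, and "the series" means these few. Any claim that something is new, unique, unknown or untested is made for them only; others in the source may bear on it.

The measured compounds, all tested in a functional assay on PC-3 cells (Homo sapiens) for cytotoxicity, read by MTT assay, with a stated time of 72 h; a higher number here means a weaker inhibitor, a lower number a stronger inhibitor:
compound 1, `FC(F)(F)c1ccc(CSc2nc(N3CCCCC3)c3ccccc3n2)cc1`, gives 25500 nM;
compound 2, `CCOc1ccccc1Nc1nc(SCc2ccc(C(F)(F)F)cc2)nc2ccccc12`, gives 26200 nM;
compound 3, `FC(F)(F)c1ccc(CSc2nc(Nc3cccc(C(F)(F)F)c3)c3ccccc3n2)cc1`, gives 12900 nM.

Compound 3 has the lowest of the three numbers, but its lead over compound 1 is only a 2.0-fold lower number from compound 1 to compound 3 (0.30 log units; within the scatter), which lies within the usual scatter, and its lead over compound 2 is a 2.0-fold lower number from compound 2 to compound 3 (0.31 log units; beyond the scatter), a modest step just beyond it. The whole set therefore sits in a narrow band, and swapping the group attached to the nitrogen of the shared core, as in a 1.0-fold higher number from compound 1 to compound 2 (0.01 log units; within the scatter), has so far moved the numbers very little.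

Compound 4, `FC(F)(F)c1ccc(CSc2nc(Nc3cccc(Br)c3)c3ccccc3n2)cc1`, keeps everything of compound 3 except one group on the anilino ring: bromo in place of trifluoromethyl on an aromatic carbon. Among the measured compounds shown here, none of the measured steps makes this exact exchange, so the expectation rests on the general observation that changes around this part of the molecule have shifted this assay by no more than a factor within or barely beyond the scatter. A comparable outcome is expected here, giving an estimated step of a 1.1-fold higher number from compound 3 to compound 4 (0.04 log units; within the scatter).

Compound 4 is therefore expected to give about 14000 nM, within a range of 6000 nM to 35000 nM.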

Compound 4, half-maximal inhibitory concentration: 8680 nM
The estimate for compound 4 lay 1.6-fold (0.21 log units) above the measured number, within the range that was stated.
By their numbers in this assay, from the lowest: compounds 4, 3, 1 and 2 (each within the scatter of the next, the first and the last beyond it).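

Trifluoromethyl, with its four heavy atoms, and bromo, a single heavy atom, cannot be told apart at this aromatic carbon in this assay, since the exchange gives a 1.5-fold lower number from compound 3 to compound 4 (0.17 log units; within the scatter) and so stays within the usual scatter. The new result still adds something at the level of the whole group: compound 1 stood within the scatter of compound 3, whereas the (3-bromophenyl)amino group gives a 2.9-fold lower number from compound 1 to compound 4 (0.47 log units; beyond the scatter) in place of piperidin-1-yl, and the 3-bromophenyl group gives a 3.0-fold lower number from compound 2 to compound 4 (0.48 log units; beyond the scatter) in place of 2-ethoxyphenyl, both modest steps beyond the scatter. Nothing presented here bears on the reason for these differences.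

Among the compounds shown here, with only two groups compared at this aromatic carbon, it remains open whether a methoxy group, a nitrile or an amine there would move the number further than bromo does. As far as these compounds go, it is also open whether bromo would hold its standing at another carbon of the same ring, or whether a chlorine or iodine atom in its place would give a similar number.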